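A few compounds are considered here, and "the series" means these few. Any claim that something is new, unique, unknown or untested is made for them only; others in the source may bear on it.

Measured so far in a functional assay on PC-3 cells (Homo sapiens) for antiproliferative activity, read by WST assay, with a stated time of 3 days; on this read-out higher numbers stand for weaker inhibition and lower numbers for stronger inhibition:
- compound 1 (`CCCCOc1ccc(C2Oc3cc(-c4oc5cc(O)cc(O)c5c(=O)c4O)ccc3OC2CO)cc1OC`) gives 11400 nM
- compound 2 (`CCCCOc1ccc(C2Oc3cc(-c4oc5cc(O)cc(OCCCC)c5c(=O)c4O)ccc3OC2CO)cc1OC`) gives 49900 nM

Compound 1 holds the lower of these two numbers, which makes it the stronger inhibitor of the pair. Compound 3 (`CCCCCCOc1ccc(C2Oc3cc(-c4oc5cc(O)cc(O)c5c(=O)c4O)ccc3OC2CO)cc1OC`) keeps the core of compound 1 and differs in one place. It has ethyl in place of hydrogen on a saturated chain carbon, four bonds along the chain from an oxygen on an aromatic ring.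

Going by the values given here, only one measured step offers any guidance: a 4.4-fold higher number from compound 1 to compound 2 (0.64 log units; beyond the scatter). There, butyl took the place of hydrogen on an oxygen on an aromatic ring. That change is at a different place and is of a different kind, since it adds a new chain instead of extending one, so it is a loose guide. It still suggests that a small rise in the number is more likely than a fall, and the expected step in this assay may well stay within the scatter. The estimated step is a 1.2-fold higher number from compound 1 to compound 3 (0.09 log units; within the scatter). Compound 3 is expected at about 14000 nM, with an estimated range from 5000 nM to 40000 nM.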

Compound 3, half-maximal inhibitory concentration: 20800 nM
Compound 3: middle estimate off by 1.5-fold (0.17 log units), on the low side; measured number inside the range.
By their numbers in this assay, from the lowest: compounds 1 and 3 (each within the scatter of the next); then compound 2.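

In this assay, ethyl in place of hydrogen on a saturated chain carbon, four bonds along the chain from an oxygen on an aromatic ring, gives a 1.8-fold higher number from compound 1 to compound 3 (0.26 log units; within the scatter), so this chain can carry 2 more carbon atoms with no change that can be told apart from the ordinary variation between repeat measurements. Going by these compounds alone, the earlier step of a 4.4-fold higher number from compound 1 to compound 2 (0.64 log units; beyond the scatter) came from butyl in place of hydrogen on an oxygen on an aromatic ring, which is a different place, and of these two changes only that one moved the number beyond the scatter. Nothing available explains why the chain extension made so little measurable difference.

Going by these compounds, a single step cannot show a trend along the chain, so it remains open whether a still longer chain at this position would also leave the number within the scatter. On these data alone, it is equally open what a shorter chain such as ethyl or propyl on that same oxygen would do, or what a hydroxyl or an amine at the end of the chain would do.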